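Vinyl in place of chloroethyl on the benzylamide carbonyl

The compounds below may be only part of what the source reports. "The series", "measured", "known", "first", "only" and "open" are said of these compounds alone.

Measured compounds in a functional assay on M21 cells (Homo sapiens) for antiproliferative activity, with a stated time of 48 h; on this read-out higher numbers stand for weaker inhibition and lower numbers for stronger inhibition:
compound 1 `CC(C)(C)c1ccc(CNC(=O)NCCCCl)cc1`: 11000 nM
compound 2 `CC(C)(C)c1ccc(CNC(=O)CCCl)cc1`: a limit of the assay, > 100000 nM
compound 3 `C=CC(=O)Nc1ccc(C(C)(C)C)cc1`: 22000 nM

Going by the values given here, compound 2 stands at the bottom of the series as a limit rather than a number; it is the one value that sits at the limit of > 100000 nM in this assay, at which 1 of the 3 values shown sits. Among the compounds with values here, the only measured step, an at least 9.0-fold higher number from compound 1 to compound 2 (0.95 log units; beyond the scatter), runs into that limit, so its true size is unknown beyond the stated minimum.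

Compound 4 `C=CC(=O)NCc1ccc(C(C)(C)C)cc1` differs from compound 2 by vinyl in place of 2-chloroethyl on a carbonyl carbon. Within the data shown here, no measured step covers this exchange. What the measured values offer is indirect: compound 3, which also carries a vinylcarbonyl, gives 22000 nM in this assay, and compound 1 gives 11000 nM. Both lie well inside the measurable range, which is the only anchor for an expectation.

Compound 4 is therefore expected to return a number near 30000 nM, within 8000 nM to 100000 nM. This corresponds to an expected at least 3.3-fold lower number from compound 2 to compound 4 (0.52 log units; beyond the scatter), with a real chance that the assay again reports only a limit.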

Compound 4, half-maximal inhibitory concentration: 72000 nM
The estimate for compound 4 lay 2.4-fold (0.38 log units) below the measured number; the measured number falls inside the stated range.
By their numbers in this assay, from the lowest: compounds 1 and 3 (each within the scatter of the next); then compound 4. At a limit, above all of these: compound 2.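

Compound 2 stands only at a limit of the assay: the limit of > 100000 nM in this assay, at which 1 of the 4 values shown sits.

In this assay, compound 4 returns a number, so vinyl in place of 2-chloroethyl on a carbonyl carbon gives an at least 1.3-fold lower number from compound 2 to compound 4 (0.14 log units; that floor lies within the scatter), a floor that does not by itself show a change. The new information at this carbonyl carbon is the comparison with the (3-chloropropyl)amino group: vinyl in its place gives a 6.5-fold higher number from compound 1 to compound 4 (0.82 log units; beyond the scatter), so compound 1 keeps the lower number against both the vinyl and the 2-chloroethyl groups.

As far as these compounds go, the true size of the exchange from 2-chloroethyl to vinyl stays open beyond its floor. Also open, from the compounds shown here alone, is how much of the gap to compound 1 follows the terminal chlorine, a question that a plain propylamino group or an ethyl group on the same carbonyl carbon would address.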